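This account rests on a few compounds, and the source may have more. Where it says the series, first, only, none or still open, it means among the compounds named here.

Working notes on the stilbene series in a functional assay on A549 cells (Homo sapiens) for cytotoxicity; a higher number here means that more compound is needed for the effect, a lower number that less compound is needed.

Compound 1 `COc1cc(/C=C/c2ccc(C(C)C)cc2)cc(OC)c1OC` gives 9.8 uM in this assay. Compound 2 `COc1cc(/C=C/c2ccc(C(C)(C)C)cc2)cc(OC)c1OC` returns only a limit in this assay, > 25 uM. The change from compound 1 to compound 2 is methyl in place of hydrogen on a saturated chain carbon bound to an aromatic carbon and two saturated chain carbons, and the step of an at least 2.5-fold higher number from compound 1 to compound 2 (0.40 log units; beyond the scatter) rests on (the limit of > 25 uM in this assay, at which 1 of the 3 values shown sits), so its true size is not fixed.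

Going by the values given here, compound 3 `CCOc1ccc(/C=C\c2cc(OC)c(OC)c(OC)c2)cc1` gives 1.6 uM in this assay, the lowest number of the two so far. The difference between the core of compound 3 and the core of compound 1 is not broken down here.

Compound 4 `CCCOc1ccc(/C=C\c2cc(OC)c(OC)c(OC)c2)cc1` is still to be measured in this assay. It differs from compound 3 by methyl in place of hydrogen on a saturated chain carbon, two bonds along the chain from an oxygen on an aromatic ring. This is the same kind of change as from compound 1 to compound 2, but the place differs: there the methyl entered on a saturated chain carbon bound to an aromatic carbon and two saturated chain carbons, here on a saturated chain carbon two bonds along the chain from an oxygen on an aromatic ring. Given that the one measured step of this kind, an at least 2.5-fold higher number from compound 1 to compound 2 (0.40 log units; beyond the scatter), weakened the effect, a smaller step in the same direction is expected, a 1.6-fold higher number from compound 3 to compound 4 (0.19 log units; within the scatter). For compound 4 the expected value is 2.5 uM, with a range from 0.8 uM to 8 uM.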

Compound 4, concentration for half-maximal effect: 3.9 uM
Beside the measured number, compound 4's estimate is 1.6-fold (0.19 log units) below it; the measured number falls inside the stated range.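

On the core of compound 3, methyl in place of hydrogen, here ethoxy to propoxy, gives a 2.4-fold higher number from compound 3 to compound 4 (0.39 log units; beyond the scatter) in this assay, so the number goes up on both cores, although the methyl enters at a different place on each. Set side by side, the two steps read: the same change on two cores in this assay, an at least 2.5-fold higher number (0.40 log units; beyond the scatter) from compound 1 to compound 2 and a 2.4-fold higher number (0.39 log units; beyond the scatter) from compound 3 to compound 4; the limit leaves it open whether they differ. Compound 2 gives > 25 uM, which is a limit of the assay and not a number, so the two pairs show a shared direction on these two cores only and do not show that the size of the step carries over from one core to the other.

From the compounds shown here alone, it remains open whether a longer chain than propoxy on the core of compound 3 would raise the number further in this assay, and whether an amine or a carboxylic acid in place of the added methyl would move it the same way. Also open, going by these compounds, is whether ethoxy to propoxy would give a like step on the core of compound 1.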